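This account rests on a few compounds, and the source may have more. Where it says the series, first, only, none or still open, it means among the compounds named here.

Compound 1 `O=C(NOCc1ccccc1F)c1cn(-c2ccccc2)nc1-c1ccccc1`, 16100 nM. Compound 2 `O=C(NOCc1ccccc1Cl)c1cn(-c2ccccc2)nc1-c1ccccc1`, 7410 nM. Compound 3 `Cc1ccc(-c2nn(-c3ccccc3)cc2C(=O)NOCc2ccccc2F)cc1`, 2110 nM.

All three were measured in a functional assay on MCF7 cells (Homo sapiens) for antiproliferative activity, read by MTT assay, with a stated time of 48 h, in the presence of a further agent that is not named here; a higher number here means a weaker inhibitor of growth, a lower number a stronger inhibitor of growth. Compound 4 `Cc1ccc(-c2nn(-c3ccccc3)cc2C(=O)NOCc2ccccc2Cl)cc1` is not yet measured. From compound 1 to compound 2 the change is chloro in place of fluoro on an aromatic carbon, which gave a 2.2-fold lower number from compound 1 to compound 2 (0.34 log units; beyond the scatter). The core of compound 3 differs from that of compound 1 by methyl in place of hydrogen on an aromatic carbon, which gave a 7.6-fold lower number from compound 1 to compound 3 (0.88 log units; beyond the scatter). Compound 4 arises from compound 3 by chloro in place of fluoro on an aromatic carbon, the same change as from compound 1 to compound 2, at the same kind of place. Among the measured compounds shown here, only that single earlier step is available, so the expectation rests on it alone. For the measured compounds named here, the expected step is a 2.1-fold lower number from compound 3 to compound 4 (0.32 log units; beyond the scatter), because the one earlier instance of this change gave a 2.2-fold lower number from compound 1 to compound 2 (0.34 log units; beyond the scatter). Compound 4 is therefore estimated at 1000 nM in this assay, expected to fall between 400 nM and 2500 nM.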

Compound 4, concentration for 50% growth inhibition: 2640 nM
Compound 4: the middle estimate sits 2.6-fold (0.42 log units) below what was measured, outside the stated range (above it).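

Chloro in place of fluoro did not repeat its earlier effect on the core that carries the methyl, giving a 1.3-fold higher number from compound 3 to compound 4 (0.10 log units; within the scatter), so in this assay the result of this change depends on the core: the same change on two cores in this assay, a 2.2-fold lower number (0.34 log units; beyond the scatter) from compound 1 to compound 2 and a 1.3-fold higher number (0.10 log units; within the scatter) from compound 3 to compound 4, 2.7-fold (0.43 log units) apart, beyond the scatter of two such steps. The methyl step kept its direction but was smaller once chloro was present, giving a 2.8-fold lower number from compound 2 to compound 4 (0.45 log units; beyond the scatter): the same change on two cores in this assay, a 7.6-fold lower number (0.88 log units; beyond the scatter) from compound 1 to compound 3 and a 2.8-fold lower number (0.45 log units; beyond the scatter) from compound 2 to compound 4, 2.7-fold (0.43 log units) apart, beyond the scatter of two such steps. The two changes therefore do not simply add up across these four compounds, but this set cannot show why, nor whether the same would hold for other groups.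

The compounds shown leave open how a bromo or a methoxy group would behave in place of the chloro. They also leave open whether an ethyl or a methoxy group in place of the methyl would depend on the core in the same way.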